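Adding a cyclopropylethynyl arm to a purinone core

The source may hold more compounds than are shown below. What is called first, only, known or untested is meant among the compounds shown, and "the series" means these compounds.

The shared core of compound 1 `O=c1nc2c(cn1Cc1ccccc1)ncn2Cc1ccccc1` is a fused two-ring system carrying two benzyl groups. For the measured compounds named here, in a functional assay on K562 cells (Homo sapiens) for cytotoxicity, read by thymidine incorporation, with a stated time of 5 h, tested at 1.25 ug/mL (on this read-out higher numbers stand for more inhibition at the one concentration tested (going by the name of the read-out) and lower numbers for less inhibition), compound 1 gives 4.4%, the lowest of the two numbers measured so far. Going by the values given here, its nearest neighbour, compound 2 `O=C1Nc2c(ncn2Cc2ccccc2)C(C#CC2CC2)N1Cc1ccccc1`, gives 35% in this assay, a gap beyond the usual scatter; compound 2 differs from compound 1 in more than one place, so no single step between them is drawn here. Compound 3 `O=c1nc2c(ncn2Cc2ccccc2)c(C#CC2CC2)n1Cc1ccccc1` differs from compound 1 in one place: 2-cyclopropylethynyl in place of hydrogen on an aromatic carbon. Among the compounds with values here, no step between measured compounds exists to guide the expectation, so only the two values above serve. The expected step of a number 20.6 percentage points higher from compound 1 to compound 3 (beyond the scatter) points upward and beyond the scatter. Compound 3 is estimated to give 25% in this assay, within a range from 5% to 50%.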

Compound 3, a percentage reported as inhibition, at one concentration (the size of the read-out at that concentration, not a potency): 98%
Estimate against measurement, compound 3: 73 percentage points below; measured number above the stated range.
By their numbers in this assay, from the lowest: compound 1; then compound 2; then compound 3.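

In this assay, exchanging one hydrogen for 2-cyclopropylethynyl on the aromatic carbon next to the ring nitrogen gives a number 93.6 percentage points higher from compound 1 to compound 3 (beyond the scatter). This shows that a change at this single position of the shared core, with both benzyl groups left in place, is enough to take the compound from little inhibition to strong inhibition at the one concentration tested, though this read-out gives no potency. Nothing available explains why this group has so large an effect.

On these data alone, it remains open which part of the group matters, the triple bond or the three-membered ring, and a plain ethynyl, a longer straight carbon chain or an amine on the same carbon could help to separate these possibilities. How the group would behave at other positions of the core is also unknown.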